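Swapping the aryl group on a prostaglandin D2 receptor antagonist

The source may report more compounds than this note shows. Statements on the series, on what has been measured and on what is new or still open speak of the compounds shown alone.

Measured so far:
- compound 1, `O=C(O)Cc1sc(C(c2ccc(F)cc2)c2ccc(F)cc2)nc1-c1cccc(F)c1`: 18 nM
- compound 2, `CS(=O)(=O)Nc1cccc(-c2nc(C(c3ccc(F)cc3)c3ccc(F)cc3)sc2CC(=O)O)c1`: 370 nM

Both compounds were tested in an in vitro functional assay on HEK285-7 cells for antagonist activity at prostaglandin D2 receptor 2 (Homo sapiens), read by BRET and beta-arrestin recruitment; a lower number here means a stronger inhibitor, a higher number a weaker inhibitor. Compound 1 gives 18 nM, and compound 2 gives 370 nM. Of the two numbers, compound 2 stands at the higher one, so it is the weaker inhibitor; the step of a 21-fold higher number from compound 1 to compound 2 (1.31 log units; beyond the scatter) shows a large loss when the fluoro on the pendant phenyl ring is exchanged for methanesulfonamido.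

Compound 3, `O=C(O)Cc1sc(C(c2ccc(F)cc2)c2ccc(F)cc2)nc1-c1ccoc1`, takes a different route: furan-3-yl in place of 3-(methanesulfonamido)phenyl on an aromatic carbon. The whole six-membered ring with its sulfonamide leaves and a small five-membered heteroaromatic ring enters at the same position of the shared core.

Among the measured compounds shown here, only the step from compound 1 to compound 2 bears on this change, and only indirectly, since it shows how sensitive this assay is to what sits at that position. Because that step, a 21-fold higher number from compound 1 to compound 2 (1.31 log units; beyond the scatter), was so large for a change of one substituent, a full ring exchange could move the number far in either direction. The estimate leans toward regaining some potency, with a step of a 3.7-fold lower number from compound 2 to compound 3 (0.57 log units; beyond the scatter) expected. Compound 3 is therefore expected to give about 100 nM, within a range of 20 nM to 600 nM.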

Compound 3, half-maximal inhibitory concentration: 130 nM
The estimate for compound 3 lay 1.3-fold (0.11 log units) below the measured number; the range from low to high includes it.
By their numbers in this assay, from the lowest: compound 1; then compound 3; then compound 2.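

Within this assay, a whole-ring exchange at this position gives a 2.8-fold lower number from compound 2 to compound 3 (0.45 log units; beyond the scatter), so a six-membered aromatic ring carrying a sulfonamide is not needed here, and a small five-membered aromatic ring with one hetero atom can take its place. The furan-3-yl group does not match the 3-fluorophenyl group, however, giving a 7.2-fold higher number from compound 1 to compound 3 (0.86 log units; beyond the scatter), so the group with the fewest heavy atoms of the three does not give the lowest number. Nothing measured here explains either difference.

The compounds shown leave open how much of the difference between the 3-(methanesulfonamido)phenyl and furan-3-yl groups belongs to the ring itself and how much to the sulfonamide on it, a question that an unsubstituted phenyl group at this position would help to settle. Also open, on these data alone, is whether the ring oxygen of the furan-3-yl group matters at all, which a thiophen-3-yl group, with sulfur in place of that oxygen, would test directly.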